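The source may report more compounds than this note shows. Statements on the series, on what has been measured and on what is new or still open speak of the compounds shown alone.

Measured compounds in an assay on CHO cells for displacement of a labelled ligand from prostaglandin D2 receptor 2 (Homo sapiens), read by scintillation counting; on this read-out lower numbers stand for stronger inhibition and higher numbers for weaker inhibition:

compound 1 `CCCc1ccncc1C#Cc1cc(Cl)ccc1OCC(=O)O`: 4.3 nM
compound 2 `Cc1ccc(S(=O)(=O)N2CCOCC2)cc1C#Cc1cc(Cl)ccc1OCC(=O)O`: 3.6 nM
compound 3 `O=C(O)COc1ccc(Cl)cc1C#Cc1cccnc1`: 117 nM

Compound 2 gives the lowest of the three numbers in this assay, but its value and that of compound 1 lie within the scatter of each other, so the two cannot be ordered. Compound 3 stands apart from both, beyond the scatter. Going by the values given here, the one single-point step seen so far is a 27-fold higher number from compound 1 to compound 3 (1.43 log units; beyond the scatter), a change at the core carried by the propyl group, not at the substituted aryl ring that compound 2 carries on the alkyne.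

Compound 4 `Cc1ccc(S(C)(=O)=O)cc1C#Cc1cc(Cl)ccc1OCC(=O)O` differs from compound 2 in one place:
methyl in place of morpholin-4-yl on a sulfonyl sulfur
The (morpholin-4-yl)sulfonyl of compound 2 thus becomes a methylsulfonyl. Among the compounds with values here, no measured pair in this assay covers a change on a sulfonyl sulfur, and the step from compound 1 to compound 3 concerns another part of the molecule, so it gives no direct guide. With the sulfonyl itself retained and the rest of the structure unchanged, the expectation is a step within the scatter, a 1.3-fold higher number from compound 2 to compound 4 (0.10 log units; within the scatter), in either direction. Compound 4 is therefore estimated at 4.5 nM in this assay, with a range of 1.5 nM to 14 nM.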

Compound 4, inhibition constant: 5 nM
Estimate against measurement, compound 4: 1.1-fold (0.05 log units) below, and the stated range covers the measured number.
By their numbers in this assay, from the lowest: compounds 2, 1 and 4 (each within the scatter of the next); then compound 3.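

In this assay, going by these compounds alone, the first reading on this sulfonyl sulfur is a 1.4-fold higher number from compound 2 to compound 4 (0.14 log units; within the scatter) for the exchange of (morpholin-4-yl)sulfonyl for methylsulfonyl. A morpholin-4-yl of 6 heavy atoms, with its six-membered non-aromatic ring and hydrogen-bond acceptor, can thus give way to a methyl of 1 heavy atom with the two values remaining indistinguishable, so in this pair the ring on the sulfur makes no readable difference to the number. Nothing on hand explains this result.

On these data alone, the pair covers only the two ends of a size range on the sulfur, so it remains open whether a primary amine, a dimethylamino group, a piperazine or a longer chain such as butyl would also leave the number within the scatter of compound 2 and compound 4. Also open, as far as these compounds go, is whether the sulfonyl itself matters, which would take a comparison in which hydrogen, a nitrile or a carboxylic acid stands on the aromatic carbon in place of the whole methylsulfonyl.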